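A few compounds are considered here, and "the series" means these few. Any claim that something is new, unique, unknown or untested is made for them only; others in the source may bear on it.

In a functional assay on HO8910 cells (Homo sapiens) for inhibition, read by MTT assay, with a stated time of 24 h, tested at 10 ug/mL (on this read-out lower numbers stand for less inhibition of growth and higher numbers for more inhibition of growth at the one concentration tested), compound 2 (`O=C(CCCCC(S)CCS)Nc1ccccc1`) gives 5.49%, compound 3 (`O=C(CCCCC(S)CCS)Nc1ccc(F)cc1`) gives 6.81% and compound 1 (`O=C(CCCCC1CCSS1)Nc1ccc(OC(F)(F)F)cc1`) gives 8.57%, so compound 3 stands within the scatter of both others. Compound 4 (`O=C(CCCCC(S)CCS)Nc1ccc(OC(F)(F)F)cc1`) keeps the core of compound 3 and has trifluoromethoxy in place of fluoro on an aromatic carbon, (trifluoromethoxy in place of fluoro on an aromatic carbon). The nearest measured change on that carbon is a number 1.3 percentage points higher from compound 2 to compound 3 (within the scatter). Compound 1 already carries trifluoromethoxy, though on a different core, and its value lies close to that of compound 3. No step beyond the scatter is therefore expected, and the estimated change is a number 1.2 percentage points higher from compound 3 to compound 4 (within the scatter). Compound 4 is expected to give about 8%, within an estimated range of 2% to 16%.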

Compound 4, percent growth inhibition at one concentration: 6.11%
The estimate for compound 4 lay 1.9 percentage points above the measured number; the measured number falls inside the stated range.
By their numbers in this assay, from the lowest: compounds 2, 4, 3 and 1 (each within the scatter of the next).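

In this assay, trifluoromethoxy in place of fluoro on this aromatic carbon gives a number 0.7 percentage points lower from compound 3 to compound 4 (within the scatter) and trifluoromethoxy in place of hydrogen gives a number 0.6 percentage points higher from compound 2 to compound 4 (within the scatter) at this place, so a group of 5 heavy atoms here does not separate from a single fluorine or from hydrogen. Replacing the five-membered ring group on the saturated chain carbon with its open-chain form gives a number 2.5 percentage points lower from compound 1 to compound 4 (within the scatter) in the same read-out. Nothing measured here explains these small differences. From the compounds shown here alone, whether an amine or a carboxylic acid on this aromatic carbon would produce a step beyond the scatter stays open.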